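The source may report more compounds than this note shows. Statements on the series, on what has been measured and on what is new or still open speak of the compounds shown alone.

Measured so far in a functional assay on T98G cells (Homo sapiens) for cytotoxicity, read by MTT assay, with a stated time of 48 h; on this read-out lower numbers stand for stronger inhibition and higher numbers for weaker inhibition:
- Compound 1 `C/C(=N\NC(=S)Nc1ccc(Cl)cc1)c1ccccn1`: 5.9 nM
- Compound 2 `C/C(=N/NC(=S)Nc1ccc(Cl)cc1)c1ccccn1`: 5.9 nM
- Compound 3 `CC(=NNC(=S)Nc1ccc(I)cc1)c1ccccn1`: 64 nM

Compound 3 gives the highest number of the three, so it is the weakest inhibitor measured so far, and its gap to each of the other two lies beyond the usual scatter. The next compound to consider is compound 4 `CC(=NNC(=S)Nc1ccc(Cl)cc1)c1ccccn1`. The change from compound 3 is small: chloro in place of iodo on an aromatic carbon, with chloro in place of iodo on an aromatic carbon, para to a large group. Compound 4 thus carries the chloro found in compounds 1 and 2, and its double bond is drawn with no configuration.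

Among the measured compounds shown here, the one measured step that bears on this is no change at the digits printed from compound 1 to compound 2 (within the scatter). That pair offers (the fact that compounds 1 and 2 differ only in the configuration as drawn), so the drawn configuration made no visible difference here. Compound 4 should therefore fall close to compound 1 at 5.9 nM, whichever configuration it has. The expected change is an 11-fold lower number from compound 3 to compound 4 (1.04 log units; beyond the scatter), a clear move to a lower number and stronger inhibition. For compound 4 the estimated value is 5.9 nM, with an expected range of 3 nM to 12 nM.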

Compound 4, half-maximal inhibitory concentration: 5.9 nM
For compound 4 middle estimate and measured number coincide at the digits printed; measured number inside the range.
By their numbers in this assay, from the lowest: compounds 1, 2 and 4 (each within the scatter of the next); then compound 3.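

In this assay, the group on the aromatic carbon, para to a large group, clearly matters: with the double bond drawn without a configuration in both compounds, chloro in place of iodo gives an 11-fold lower number from compound 3 to compound 4 (1.04 log units; beyond the scatter). The earlier compounds shown here could not show this, since compound 3 differed from compounds 1 and 2 in how the double bond was drawn as well as in this group. Leaving the configuration undrawn also shows no visible effect, with no change at the digits printed from compound 1 to compound 4 (within the scatter) and no change at the digits printed from compound 2 to compound 4 (within the scatter).

As far as these compounds go, only chloro and iodo are compared at this position, so it stays open how a fluoro, a methoxy or an amine there would read. From the compounds shown here alone, it also stays open whether the same change would give a similar step with a different group elsewhere on the shared core.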